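The source may hold more compounds than are shown below. What is called first, only, known or untested is meant among the compounds shown, and "the series" means these compounds.

Of the compounds shown here, three have so far been tested in a functional assay, read by spectrophotometry, with a stated time of 30 min; on this read-out higher numbers stand for an effect only at larger amounts of compound and lower numbers for an effect already at smaller amounts. Compound 1, `COCCCN1C(/C=C/c2ccc(O)cc2)=CC(=O)CC1c1ccc(O)cc1`, gives > 200000 nM, which is a limit of the assay rather than a number. Compound 3, `O=C(/C=C(/C=C/c1ccc(O)cc1)NCCO)/C=C/c1ccc(O)cc1`, likewise reaches only the limit > 200000 nM. Among the compounds with values here, compound 2, `COc1cc(/C=C/C(=O)/C=C(/C=C/c2ccc(O)c(OC)c2)NCCO)ccc1O`, gives 28300 nM, the only number among the three. The other two values sit at the limit of > 200000 nM in this assay, at which 2 of the 3 values shown sit. Compound 4, `COCCCNC(=C\C(=O)/C=C/c1ccc(O)c(OC)c1)/C=C/c1ccc(O)c(OC)c1`, differs from compound 2 in a single place: methoxymethyl in place of hydroxy on a saturated chain carbon, two bonds along the chain from an amine nitrogen. Within the data shown here, no measured pair shows this change, so nothing here tells how much it shifts the read-out. Compound 4 is therefore expected to stay within the usual scatter of compound 2, the step of a 1.1-fold higher number from compound 2 to compound 4 (0.03 log units; within the scatter) being no larger than that scatter. Compound 4 is estimated at 30000 nM, within a range from 10000 nM to 120000 nM.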

Compound 4, half-maximal effective concentration in the functional assay: 29500 nM
For compound 4 the middle estimate is 1.0-fold (0.01 log units) above the measured one; the range from low to high includes it.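

In the functional assay the swap of hydroxy for methoxymethyl on a saturated chain carbon, two bonds along the chain from an amine nitrogen, gives a 1.0-fold higher number from compound 2 to compound 4 (0.02 log units; within the scatter), so this position takes the longer chain, which has no hydrogen-bond donor, without a readable shift. In a physicochemical assay for solubility, using the shake flask method, in phosphate buffer, with a stated time of 90 min, at pH 6.8 (a lower number here means a less soluble compound, a higher number a more soluble compound), compound 2 gives 8140 nM and compound 4 gives 7700 nM, two values within the usual scatter of each other. Neither end of this step is a limit of the assay, unlike compound 1 and compound 3: the limit of > 200000 nM in the functional assay, at which 2 of the 4 values shown sit.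

Going by these compounds, whether an amine or a carboxylic acid in place of the hydroxy would move either read-out stays open.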